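Replacing the nitrooxyphenyl of compound 3 with a hydroxy-methoxyphenyl

A few compounds are considered here, and "the series" means these few. Any claim that something is new, unique, unknown or untested is made for them only; others in the source may bear on it.

Of the compounds shown here, three sharing one core have been measured in a functional assay on HT-29 cells (Homo sapiens) for cytotoxicity, read by MTT assay, with a stated time of 72 h; a lower number here means a stronger inhibitor, a higher number a weaker inhibitor. Compound 1 `CN(C)CCn1cnnc1-c1cc(Oc2ccc(NC(=O)N/N=C/c3cccc(O)c3)cc2F)ccn1` gives 330 nM, compound 2 `CN(C)CCn1cnnc1-c1cc(Oc2ccc(NC(=O)N/N=C/c3ccc(Cl)cc3)cc2F)ccn1` gives 530 nM, and compound 3 `CN(C)CCn1cnnc1-c1cc(Oc2ccc(NC(=O)N/N=C/c3ccccc3O[N+](=O)[O-])cc2F)ccn1` gives 950 nM. Compound 3 carries the highest number of the three: one step leading to it is a 1.8-fold higher number from compound 2 to compound 3 (0.25 log units; within the scatter), which lies within the scatter, while the other is a 2.9-fold higher number from compound 1 to compound 3 (0.46 log units; beyond the scatter), a modest weakening that lies beyond it.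

Compound 4 `COc1ccc(/C=N/NC(=O)Nc2ccc(Oc3ccnc(-c4nncn4CCN(C)C)c3)c(F)c2)cc1O` has not yet been measured. It differs from compound 3 in one place: 3-hydroxy-4-methoxyphenyl in place of 2-(nitrooxy)phenyl on a carbon with a double bond to nitrogen.

For the measured compounds named here, no measured step matches this change exactly. The step that comes closest is the one that brought the 2-(nitrooxy)phenyl in, a 2.9-fold higher number from compound 1 to compound 3 (0.46 log units; beyond the scatter), since compound 4 keeps the hydroxyl of compound 1 while adding a methoxy group. The other step leaving the same group, a 1.8-fold higher number from compound 2 to compound 3 (0.25 log units; within the scatter), lies within the scatter. The effect of the added methoxy group is not covered by any measured pair.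

On this basis compound 4 is expected to show a lower number than compound 3, by roughly the size of the earlier step, a 2.4-fold lower number from compound 3 to compound 4 (0.38 log units; beyond the scatter). The estimate for compound 4 is 400 nM, with a range from 150 nM to 1100 nM.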

Compound 4, half-maximal inhibitory concentration: 960 nM
The estimate for compound 4 lay 2.4-fold (0.38 log units) below the measured number, within the range that was stated.
By their numbers in this assay, from the lowest: compounds 1, 2, 3 and 4 (each within the scatter of the next, the first and the last beyond it).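

Adding a single methoxy group in place of hydrogen on an aromatic carbon of the 3-hydroxyphenyl ring gives a 2.9-fold higher number from compound 1 to compound 4 (0.46 log units; beyond the scatter) in this assay, so keeping the hydroxyl does not by itself keep the number of compound 1. The other two steps, a 1.0-fold higher number from compound 3 to compound 4 (0.00 log units; within the scatter) and a 1.8-fold higher number from compound 2 to compound 4 (0.26 log units; within the scatter), lie within the scatter, which means that 3-hydroxy-4-methoxyphenyl, 2-(nitrooxy)phenyl and 4-chlorophenyl on this carbon with a double bond to nitrogen cannot be told apart, even though only the first of these carries a hydroxyl. No information is available that accounts for the effect of the added methoxy group.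

The compounds shown leave open whether this weakening is particular to methoxy or would also follow from a fluorine atom, an ethoxy group or an amine on the same aromatic carbon. They also leave open whether the step would be of the same size with a longer chain in place of the dimethylaminoethyl group on the shared core.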